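Methoxy for fluoro on the aromatic carbon of compound 2

The source may report more compounds than this note shows. Statements on the series, on what has been measured and on what is new or still open speak of the compounds shown alone.

Compound 2 `Fc1ccccc1C1Cc2nccn2C1` gives 42 nM in a functional assay on CHO cells for agonist activity at Alpha-1A adrenergic receptor (Homo sapiens), read by FLIPR and calcium flux (on this read-out lower numbers stand for an effect already at smaller amounts and higher numbers for an effect only at larger amounts of compound), the second highest of the three numbers in the set. Within the data shown here, compound 1 `FC(F)Oc1ccccc1C1Cc2nccn2C1` gives 11 nM, and compound 3 `Clc1ccccc1C1CCc2nc[nH]c2C1` gives 276 nM; compound 3 differs from compound 2 in more than one place, so no single step links the two. The change to compound 4 `COc1ccccc1C1Cc2nccn2C1` is methoxy in place of fluoro on an aromatic carbon. Among the measured compounds shown here, the one step that bears on it, a 3.8-fold higher number from compound 1 to compound 2 (0.58 log units; beyond the scatter), shows that difluoromethoxy on this carbon went with a lower number than fluoro. Methoxy shares the oxygen link but not the fluorines, so a smaller move in the same direction is expected. For compound 4 a step of a 2.1-fold lower number from compound 2 to compound 4 (0.32 log units; beyond the scatter) is expected. The estimate for compound 4 is 20 nM, with a range from 8 nM to 50 nM.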

Compound 4, half-maximal effective concentration: 22 nM
Compound 4: the middle estimate sits 1.1-fold (0.04 log units) below what was measured; low and high end bracket the measured number.
By their numbers in this assay, from the lowest: compounds 1, 4 and 2 (each within the scatter of the next, the first and the last beyond it); then compound 3.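

In this assay the step of a 1.9-fold lower number from compound 2 to compound 4 (0.28 log units; within the scatter) and the step of a 2.0-fold higher number from compound 1 to compound 4 (0.30 log units; within the scatter) both lie within the scatter. Compound 4 therefore cannot be ordered against compound 2 or compound 1, although those two stand apart beyond the scatter, so methoxy on this aromatic carbon does not separate from either group. No measured evidence accounts for these steps.

Still open, on these data alone, is whether an amine, a hydroxyl or a longer chain such as ethoxy on this carbon would move the number beyond the scatter from compound 4.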